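Replacing 2-methylphenyl with 3-chlorophenyl in compound 1

A few compounds are considered here, and "the series" means these few. Any claim that something is new, unique, unknown or untested is made for them only; others in the source may bear on it.

In a functional assay on HepG2 cells (Homo sapiens) for antiproliferative activity, read by MTT assay, with a stated time of 24 h (on this read-out higher numbers stand for weaker inhibition and lower numbers for stronger inhibition), compound 1 `Cc1ccccc1-n1cc(-c2ccccc2NS(=O)(=O)c2c[nH]c(=O)[nH]c2=O)nn1` gives 13900 nM and compound 2 `O=c1[nH]cc(S(=O)(=O)Nc2ccccc2-c2cn(-c3ccccc3F)nn2)c(=O)[nH]1` gives 12500 nM. These two values sit within the scatter of each other, as a 1.1-fold lower number from compound 1 to compound 2 (0.05 log units; within the scatter) shows. Compound 3 `O=c1[nH]cc(S(=O)(=O)Nc2ccccc2-c2cn(-c3ccc(F)cc3)nn2)c(=O)[nH]1` reads > 20000 nM, which is a limit of the assay and not a number.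

Compound 4 `O=c1[nH]cc(S(=O)(=O)Nc2ccccc2-c2cn(-c3cccc(Cl)c3)nn2)c(=O)[nH]1` differs from compound 1 by one change: 3-chlorophenyl in place of 2-methylphenyl on an aromatic nitrogen. Three measured steps exchange the aromatic group on that same ring nitrogen. Besides the step above, these are an at least 1.4-fold higher number from compound 1 to compound 3 (0.15 log units; that floor lies within the scatter) and an at least 1.6-fold higher number from compound 2 to compound 3 (0.20 log units; that floor lies within the scatter). Within the data shown here, neither of these two has a floor beyond the scatter, so neither fixes a size, and no measured compound carries 3-chlorophenyl.

No step beyond the scatter is therefore expected, and the estimated step in this assay is a 1.1-fold higher number from compound 1 to compound 4 (0.03 log units; within the scatter). A reading at the limit remains possible, as with compound 3 at > 20000 nM. For compound 4 the expected value is 15000 nM, with an estimated range of 8000 nM to 28000 nM.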

Compound 4, half-maximal inhibitory concentration: 2460 nM
Beside the measured number, compound 4's estimate is 6.1-fold (0.79 log units) above it; the measured number lies below the stated range.
By their numbers in this assay, from the lowest: compound 4; then compounds 2 and 1 (each within the scatter of the next). At a limit, above all of these: compound 3.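

In this assay, exchanging the aromatic group on this ring nitrogen now gives steps beyond the scatter, which no earlier measured exchange had shown: a 5.7-fold lower number from compound 1 to compound 4 (0.75 log units; beyond the scatter), and a 5.1-fold lower number from compound 2 to compound 4 (0.71 log units; beyond the scatter). The third step, an at least 8.1-fold lower number from compound 3 to compound 4 (0.91 log units; beyond the scatter), is only a floor, since compound 3 stands at a limit and not a number: the limit of > 20000 nM in this assay, at which 1 of the 4 values shown sits. Among the groups shown on this nitrogen, 3-chlorophenyl alone separates from the others, while compound 1 and compound 2 stay within the scatter of each other.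

On these data alone, whether the step belongs to the chlorine itself or to where it sits on the phenyl ring remains open. Also open, as far as these compounds go, is how 2-chlorophenyl, 4-chlorophenyl, 3-methoxyphenyl or 3-aminophenyl would read on the same nitrogen.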